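The compounds below may be only part of what the source reports. "The series", "measured", "known", "first", "only" and "open" are said of these compounds alone.

Compound 2, `Cc1cc(NC(=O)Nc2ccc(Cl)cc2)c2ccccc2n1`, is a urea whose two aromatic parts are joined through the amide; in a physicochemical assay for solubility, at pH 7.4 (on this read-out higher numbers stand for higher solubility and lower numbers for lower solubility), compound 2 gives 1400 nM. Among the compounds with values here, its only measured neighbour is compound 1, `COc1ccc(NC(=O)Nc2cc(C)nc3ccccc23)cc1`, which carries methoxy where compound 2 carries chloro, and in this assay compound 1 gives 19800 nM. Within the data shown here, of the two numbers measured so far, compound 2 therefore stands lowest, and the single step connecting them, a 14-fold lower number from compound 1 to compound 2 (1.15 log units; beyond the scatter), is a large one.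

Compound 3, `CCc1ccc(NC(=O)Nc2cc(C)nc3ccccc23)cc1`, has not yet been measured. It differs from compound 2 in one place: ethyl in place of chloro on an aromatic carbon.

Among the measured compounds shown here, only one measured step bears on this change, and only loosely, since it concerns the same position but a different exchange, methoxy giving way to chloro rather than chloro giving way to ethyl. That step was large, yet no measurement shows how ethyl compares with chloro here. A step no larger than the scatter, or a modest further drop, is expected. Compound 3 is expected to give about 1000 nM, within a range from 300 nM to 4000 nM. This estimate means an expected step of a 1.4-fold lower number from compound 2 to compound 3 (0.15 log units; within the scatter).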

Compound 3, solubility: 3300 nM
Compound 3: the middle estimate sits 3.3-fold (0.52 log units) below what was measured; the measured number falls inside the stated range.
By their numbers in this assay, from the lowest: compound 2; then compound 3; then compound 1.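

In this assay, the exchange of chloro for ethyl has a measurable effect of its own, with a 2.4-fold higher number from compound 2 to compound 3 (0.37 log units; beyond the scatter) as a modest step that lies beyond the usual scatter. Neither group carries a hydrogen-bond donor or acceptor, so those counts alone do not separate the two compounds, and the difference of a single heavy atom is still enough to go with a readable change in the number. Ethyl also does not reach the level seen with methoxy, as a 6.0-fold lower number from compound 1 to compound 3 (0.78 log units; beyond the scatter) shows, so the three groups at this position now form an order, with chloro lowest, ethyl in the middle and methoxy highest, and nothing measured here accounts for that order.

Within the data shown here, with only three groups tested at this position, it remains open where a longer chain such as propyl, an amine or a carboxylic acid would fall in this order. From the compounds shown here alone, it also remains open whether chloro, ethyl and methoxy would keep the same order if they were exchanged on a different core or at another place on this one.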